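Swapping bromo for chloro in cyclopropylmethyl benzotriazoles

A few compounds are considered here, and "the series" means these few. Any claim that something is new, unique, unknown or untested is made for them only; others in the source may bear on it.

Measured so far:
compound 1 `Brc1cccc2c1nnn2CC1CC1` gives 7.7 mL/min/g in an ADME assay on microsomes from liver (Mus musculus, strain NMRI) for metabolic stability, tested at 2.5 uM; on this read-out higher numbers stand for fast clearance and lower numbers for slow clearance
compound 2 `Brc1cc(Br)c2nnn(CC3CC3)c2c1` gives 15.3 mL/min/g
compound 3 `Clc1cc(Br)c2nnn(CC3CC3)c2c1` gives 11.4 mL/min/g

Among the measured compounds shown here, the one change that has already been measured is the one from compound 2 to compound 3: chloro in place of bromo on an aromatic carbon. It made a step of a 1.3-fold lower number from compound 2 to compound 3 (0.13 log units; within the scatter). Compound 1 carries a different core from compound 2; how the two cores differ is hydrogen in place of bromo on an aromatic carbon.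

Compound 4 `Clc1cccc2c1nnn2CC1CC1` has not been measured yet. It differs from compound 1 by chloro in place of bromo on an aromatic carbon. For the measured compounds named here, this is the same kind of change as the one from compound 2 to compound 3, but not the same: there the place was meta to a bromo group, meta to a fused ring and para to a fused ring, whereas here it is ortho to a fused ring and meta to a fused ring.

Going by the values given here, from compound 1 to compound 4 a step of a 1.2-fold lower number from compound 1 to compound 4 (0.07 log units; within the scatter) is expected, beside the measured 1.3-fold lower number from compound 2 to compound 3 (0.13 log units; within the scatter), because a 1.3-fold lower number from compound 2 to compound 3 (0.13 log units; within the scatter) is the only measured example of this kind of change, and it stayed within the scatter. For compound 4 the estimate is 6.5 mL/min/g, with a likely range from 3.5 mL/min/g to 12 mL/min/g.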

Compound 4, intrinsic clearance in a liver preparation (reported as CLH), per the amount of preparation that the assay uses: 5.7 mL/min/g
Compound 4: the middle estimate sits 1.1-fold (0.06 log units) above what was measured, and the stated range covers the measured number.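

In this assay, chloro in place of bromo gave a 1.4-fold lower number from compound 1 to compound 4 (0.13 log units; within the scatter) and so stays inside the usual scatter of repeated measurements. This does not show that the swap has a real effect on clearance, nor that the result would hold on a core beyond these two, and it gives no reason for the agreement. What it does show is that, on the two cores tested, the swap made no difference that can be told apart from the scatter, and the two steps agree with each other: the same change on two cores in this assay, a 1.3-fold lower number (0.13 log units; within the scatter) from compound 2 to compound 3 and a 1.4-fold lower number (0.13 log units; within the scatter) from compound 1 to compound 4, 1.0-fold (0.00 log units) apart, within the scatter of two such steps

The compounds shown leave open what other groups would do on that aromatic carbon, such as a nitrile, a methoxy group or an amine, since only bromo, chloro and hydrogen appear there. They also leave open whether the swap would stay this quiet on a core with a longer chain in place of the cyclopropylmethyl group.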